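The compounds below may be only part of what the source reports. "The series", "measured", "known", "first", "only" and "open" are said of these compounds alone.

Compound 1, `CC(=O)c1cc2ccc(OCCCn3cc(CNC(=O)CCCCC4CCSS4)nn3)cc2oc1=O`, gives 38%.
Compound 2, `O=C(CCCCC1CCSS1)NCc1cn(CCCCOc2ccc3cc(-c4ccccc4)c(=O)oc3c2)nn1`, gives 30.5%.
Compound 3, `CC(=O)c1cc2ccc(OCCCCCn3cc(CNC(=O)CCCCC4CCSS4)nn3)cc2oc1=O`, gives 20.8%.

All three were tested in a functional assay on PC-12 cells (Rattus norvegicus) for cytotoxicity, read by MTT assay, with stated times of 3 h and 2 h, tested at 10 uM; on this read-out higher numbers stand for a stronger effect at the one concentration tested and lower numbers for a weaker effect. Compound 3 has the lowest of the three numbers; its gap to compound 2 lies within the usual scatter, while its gap to compound 1 lies beyond it. The compound not yet measured is compound 4, `O=C(CCCCC1CCSS1)NCc1cn(CCCCCOc2ccc3cc(-c4ccc(Br)cc4)c(=O)oc3c2)nn1`. It differs from compound 3 in one place: 4-bromophenyl in place of acetyl on an aromatic carbon. Among the measured compounds shown here, no measured pair shows this exact change, so the step has to be guessed from the spread of the three values alone. The step from compound 3 to compound 4 is expected to be small, a number 5.2 percentage points higher from compound 3 to compound 4 (within the scatter), and not clearly beyond the scatter. Compound 4 is therefore estimated at 26%, within a range from 12% to 40%.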

Compound 4, a percentage reported as activity, at one concentration (the size of the read-out at that concentration, not a potency): 48.4%
Estimate against measurement, compound 4: 22.4 percentage points below, and the stated range ends below it.
By their numbers in this assay, from the lowest: compounds 3, 2 and 1 (each within the scatter of the next, the first and the last beyond it); then compound 4.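

At this position, an aromatic carbon two atoms from the ring oxygen, the choice of group clearly matters in this assay: 4-bromophenyl in place of acetyl gives a number 27.6 percentage points higher from compound 3 to compound 4 (beyond the scatter). Among the compounds shown here, this is the only single-place comparison among the four compounds, and it shows that the read-out can rise when a two-carbon acyl group gives way to an aromatic ring bearing bromine. No measurement here explains this rise.

As far as these compounds go, whether the bromine is needed remains open, as does the result with plain phenyl on this same chain. An amine or a carboxylic acid at this position also remains untested in the compounds shown.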